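The source may report more compounds than this note shows. Statements on the series, on what has been measured and on what is new or still open speak of the compounds shown alone.

Working notes on the series. Among the measured compounds shown here, in an assay on cell membranes from spleen (Cavia porcellus) for binding affinity to leukotriene B4 receptor 1 (Homo sapiens) (a lower number here means a stronger inhibitor, a higher number a weaker inhibitor), compound 2 `O=C(O)CCCCCCOc1cc(-c2ccccc2)cc(-c2ccccc2)n1` gives 25 nM, the highest of the two numbers so far; compound 1 `CC(CCCCOc1cc(-c2ccccc2)cc(-c2ccccc2)n1)C(=O)O` gives 4 nM, and the single measured step between them, a 6.3-fold higher number from compound 1 to compound 2 (0.80 log units; beyond the scatter), is the only comparison available. Compound 3 `CC(C)(CCCCCCOc1cc(-c2ccccc2)cc(-c2ccccc2)n1)C(=O)O` has not yet been measured; it differs from compound 2 by 1-carboxy-1-methylethyl in place of carboxy on a saturated chain carbon, six bonds along the chain from an oxygen on an aromatic ring. The step of a 6.3-fold higher number from compound 1 to compound 2 (0.80 log units; beyond the scatter) bears on this change and runs in the opposite direction, so a move back toward a lower number is expected for compound 3 in this assay, with the caveat that compound 3 adds two methyls and a further chain carbon where that step concerned one methyl, so the expected size is uncertain. For compound 3 the estimate in this assay is 8 nM, within a range of 2 nM to 30 nM. The expected step is a 3.1-fold lower number from compound 2 to compound 3 (0.49 log units; beyond the scatter).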

Compound 3, half-maximal inhibitory concentration: 22 nM
For compound 3 the middle estimate is 2.8-fold (0.44 log units) below the measured one; low and high end bracket the measured number.
By their numbers in this assay, from the lowest: compound 1; then compounds 3 and 2 (each within the scatter of the next).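

In this assay, 1-carboxy-1-methylethyl in place of carboxy, on a saturated chain carbon six bonds along the chain from an oxygen on an aromatic ring, gives a 1.1-fold lower number from compound 2 to compound 3 (0.06 log units; within the scatter), so this change does not separate the two compounds. The other step, a 5.5-fold higher number from compound 1 to compound 3 (0.74 log units; beyond the scatter), with 3-carboxy-3-methylbutyl in place of 1-carboxyethyl, leaves compound 1 with the lowest number of the three, at 4 nM. Nothing measured here accounts for either step.

Still open, going by these compounds, is whether a tetrazole or a primary amide in place of the carboxy group would keep the number of compound 2 or compound 3. Also open, on these data alone, is whether a cyclopropyl group in place of the two methyls of 1-carboxy-1-methylethyl would change it.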